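Swapping the para methoxy for chloro on the benzyl arm

The source may report more compounds than this note shows. Statements on the series, on what has been measured and on what is new or still open speak of the compounds shown alone.

Three compounds share a core in which a bis(trifluoromethyl)phenyl sulfonamide is linked through a three-carbon chain to a benzylamine. Compound 1 `O=S(=O)(NCCCNCc1ccccc1Cl)c1cc(C(F)(F)F)cc(C(F)(F)F)c1` gives 11000 nM in a functional assay on BXPC-3 cells (Homo sapiens) for inhibition, read by MTT assay, with a stated time of 72 h; a higher number here means a weaker inhibitor of growth, a lower number a stronger inhibitor of growth. Compound 2 `O=S(=O)(NCCCNCc1ccc(C(F)(F)F)cc1)c1cc(C(F)(F)F)cc(C(F)(F)F)c1` gives 1700 nM, and compound 3 `COc1ccc(CNCCCNS(=O)(=O)c2cc(C(F)(F)F)cc(C(F)(F)F)c2)cc1` gives 1300 nM. Compound 3 has the lowest number of the three, though its gap to compound 2 stays within the scatter; the steps of a 6.5-fold lower number from compound 1 to compound 2 (0.81 log units; beyond the scatter) and an 8.5-fold lower number from compound 1 to compound 3 (0.93 log units; beyond the scatter) separate both from compound 1.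

Compound 4 `O=S(=O)(NCCCNCc1ccc(Cl)cc1)c1cc(C(F)(F)F)cc(C(F)(F)F)c1` differs from compound 3 by chloro in place of methoxy on an aromatic carbon. The step that bears most directly on this is a 1.3-fold lower number from compound 2 to compound 3 (0.12 log units; within the scatter), which shows that exchanging one para group for another on this ring barely moves the number, while the larger steps from compound 1 concern a different substitution pattern. Compound 4 is therefore expected to sit close to compound 3, with a step of a 1.2-fold higher number from compound 3 to compound 4 (0.06 log units; within the scatter) not beyond the scatter. The estimated value for compound 4 is 1500 nM, within a range of 600 nM to 4000 nM.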

Compound 4, concentration for 50% growth inhibition: 1600 nM
Estimate against measurement, compound 4: 1.1-fold (0.03 log units) below; low and high end bracket the measured number.
By their numbers in this assay, from the lowest: compounds 3, 4 and 2 (each within the scatter of the next); then compound 1.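

With chloro, three different groups have now been tried at this ring position, and in this assay they do not separate: a 1.2-fold higher number from compound 3 to compound 4 (0.09 log units; within the scatter) and a 1.1-fold lower number from compound 2 to compound 4 (0.03 log units; within the scatter) both stay within the scatter. The new compound also shows that the chlorine alone does not set compound 1 apart, since 4-chlorophenyl in place of 2-chlorophenyl gives a 6.9-fold lower number from compound 1 to compound 4 (0.84 log units; beyond the scatter), a step beyond the scatter, so the two chloro isomers differ clearly. Nothing available explains either the flat run among these groups or the gap between the two isomers.

The compounds shown leave open whether a carboxylic acid or a dimethylamino group at this ring position would still fall within the same narrow range. They also leave open whether a longer chain in the linker would shift the number.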